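The compounds below may be only part of what the source reports. "The series", "measured", "known", "first", "only" and "open" are said of these compounds alone.

In a functional assay (T cell) with Homo sapiens as the target (a higher number here means a weaker inhibitor, a lower number a stronger inhibitor), compound 3 `C#CCN(Cc1ccc2nc(C)[nH]c(=O)c2c1)c1ccc(C(=O)N[C@@H](C[C@@H](F)C(=O)O)C(=O)O)cc1` gives 5.67 nM, level with compound 1 `Cc1nc2ccc(CN(C)c3ccc(C(=O)N[C@@H](C[C@@H](F)C(=O)O)C(=O)O)s3)cc2c(=O)[nH]1` at 5.67 nM, and these two share the lowest number of the three. Compound 2 `Nc1nc2c(c(=O)[nH]1)C[C@@H](CCc1ccc(C(=O)N[C@@H](C[C@@H](F)C(=O)O)C(=O)O)cc1)CN2` sits far higher at 2300 nM. Compound 4 `C#CCN(Cc1ccc2nc(C)[nH]c(=O)c2c1)c1ccc(C(=O)N[C@@H](C[C@H](F)C(=O)O)C(=O)O)cc1` keeps the atoms and bonds of compound 3 and differs only in configuration as drawn: the two compounds have the same atoms and bonds and differ only in configuration as drawn: 1 of 2 stereo elements differ; a stereocentre at a saturated chain carbon is drawn R in compound 3 and S in compound 4. The stereocentre at a saturated chain carbon is drawn R in compound 3 and S in compound 4. For the measured compounds named here, no measured pair isolates a change of this kind, so the expectation lacks direct precedent. The expected step of a 1.4-fold higher number from compound 3 to compound 4 (0.15 log units; within the scatter) is a small rise in the number, close to the scatter. For compound 4 the estimated value is 8 nM, with an expected range of 2.5 nM to 30 nM.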

Compound 4, half-maximal inhibitory concentration: 5.67 nM
The estimate for compound 4 lay 1.4-fold (0.15 log units) above the measured number; the range from low to high includes it.
By their numbers in this assay, from the lowest: compounds 1, 3 and 4 (each within the scatter of the next); then compound 2.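

For the compounds shown here, changing the stereocentre at a saturated chain carbon from R to S gives the first step in this assay, with no change at the digits printed from compound 3 to compound 4 (within the scatter). The drawn configuration at this stereocentre therefore does not separate the two compounds, something compounds 1 and 2 could not show. The comparison concerns configuration alone: the fact that compounds 3 and 4 differ only in the configuration as drawn

The compounds shown leave open whether a hydroxyl group in place of the fluorine would hold the number at this level. They also leave open whether the second stereocentre tolerates the same inversion.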